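From Methyl to Trifluoromethoxy in a Series at the Limit

The source may hold more compounds than are shown below. What is called first, only, known or untested is meant among the compounds shown, and "the series" means these compounds.

Compound 2 `Cc1cccc(OC[C@@H]2[C@H]3CC[C@H](c4nc(C(=O)O)cs4)O[C@H]3C[C@H]2O)c1` is the starting point here. In an assay on HEK293 cells for agonist activity at prostaglandin E2 receptor EP2 subtype (Homo sapiens), read by a beta-galactosidase reporter and beta-arrestin recruitment, with a stated time of 90 min (a lower number here means that less compound is needed, a higher number that more compound is needed for the effect), compound 2 gives only a limit, > 10000 nM, not a measured number. Compound 1 `O=C(O)c1csc([C@H]2CC[C@@H]3[C@@H](CCCCCOc4ccccc4)[C@H](O)C[C@@H]3O2)n1` likewise reaches only the limit of > 10000 nM in this assay. Compound 3 `O=C(O)c1csc([C@H]2CC[C@@H]3[C@@H](COc4ccc(F)cc4)[C@H](O)C[C@@H]3O2)n1` also stops at the limit, > 10000 nM. Among the measured compounds shown here, the one measured step, a step that the two limits leave unreadable from compound 2 to compound 3, is therefore of unknown size, since the limit of > 10000 nM in this assay, at which 3 of the 3 values shown sit, describes where every value so far sits. Compound 4 `O=C(O)c1csc([C@H]2CC[C@@H]3[C@@H](COc4cccc(OC(F)(F)F)c4)[C@H](O)C[C@@H]3O2)n1` differs from compound 2 by trifluoromethoxy in place of methyl on an aromatic carbon. For the measured compounds named here, no measured step shows what such a change does. With every value at the limit, compound 4 is expected to give about 20000 nM in this assay, within a range of 4000 nM to 100000 nM, most likely reported again as a limit. That expectation corresponds to a step that the limit leaves unreadable from compound 2 to compound 4.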

Compound 4, half-maximal effective concentration: 69 nM
Compound 4: the middle estimate sits 290-fold (2.46 log units) above what was measured, outside the stated range (below it).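

On this aromatic carbon, meta to a large group, trifluoromethoxy in place of methyl gives an at least 140-fold lower number from compound 2 to compound 4 (2.16 log units; beyond the scatter) in this assay, so a change at this one place is enough to move a compound from a limit to a measured number. Compound 4 is the only compound shown that gets past that limit: the limit of > 10000 nM in this assay, at which 3 of the 4 values shown sit.

As far as these compounds go, what a methoxy or a trifluoromethyl group on the same aromatic carbon would give stays open, so it is unclear which part of the trifluoromethoxy group matters. The step from compound 2 to compound 3 cannot be read, which leaves the 4-fluorophenyl change undecided.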